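Growth inhibition notes: compound 3 to compound 4

A few compounds are considered here, and "the series" means these few. Any claim that something is new, unique, unknown or untested is made for them only; others in the source may bear on it.

- compound 1 `COc1ccc(COc2cc(O)c3c(=O)cc(C)oc3c2[C@H]2CCN(C)C[C@H]2O)cc1`: 35%
- compound 2 `Cc1cc(=O)c2c(O)c(CN(C(C)C)C(C)C)c(O)c([C@H]3CCN(C)C[C@H]3O)c2o1`: 0%
- compound 3 `Cc1oc2c([C@H]3CCN(C)C[C@H]3O)c(O)cc(O)c2c(=O)c1C(O)c1ccc([N+](=O)[O-])cc1`: 24%

All three values come from a functional assay on PC-3 cells (Homo sapiens) for inhibition, read by MTT assay, with a stated time of 48 h, tested at 10 uM; on this read-out lower numbers stand for less inhibition of growth and higher numbers for more inhibition of growth at the one concentration tested. Compound 3 stands second highest of the three, with compound 1 above it and compound 2 below it, both gaps beyond the usual scatter. Compound 4 `Cc1oc2c([C@H]3CCN(C)C[C@H]3O)c(O)cc(O)c2c(=O)c1C(O)c1ccc(F)c(Br)c1` is still unmeasured. It differs from compound 3 as follows: 3-bromo-4-fluorophenyl in place of 4-nitrophenyl on a saturated chain carbon bound to an aromatic carbon and an oxygen on a saturated carbon. In words, this is 3-bromo-4-fluorophenyl in place of 4-nitrophenyl on a saturated chain carbon bound to an aromatic carbon and an oxygen on a saturated carbon. Among the measured compounds shown here, no measured pair of compounds shows a single change at this place. No step beyond the scatter is expected in this assay, in either direction. The estimated change is a number 4 percentage points higher from compound 3 to compound 4 (within the scatter). The expected value for compound 4 is 28%, with an estimated range from 10% to 45%.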

Compound 4, percent growth inhibition at one concentration: 72%
Compound 4: middle estimate off by 44 percentage points, on the low side; the measured number lies above the stated range.
By their numbers in this assay, from the lowest: compound 2; then compound 3; then compound 1; then compound 4.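

The aryl group on a saturated chain carbon bound to an aromatic carbon and an oxygen proves to be a sensitive place: in this assay, 3-bromo-4-fluorophenyl in place of 4-nitrophenyl gives a number 48 percentage points higher from compound 3 to compound 4 (beyond the scatter). Among the compounds shown here, this is the first single-place change read, and it shows that growth inhibition at this concentration can shift strongly with this aryl group alone. No measurement on hand accounts for the step. Still open, going by these compounds, is whether the bromine or the fluorine alone carries it, and how an amine or a carboxylic acid on the phenyl ring would read here.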